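Acetamidophenyl swap on a compound at the limit

This account rests on a few compounds, and the source may have more. Where it says the series, first, only, none or still open, it means among the compounds named here.

Values in a functional assay on MCF7 cells (Homo sapiens) for antiproliferative activity, read by MTT assay, with a stated time of 48 h; a higher number here means a weaker inhibitor, a lower number a stronger inhibitor:
Compound 1 `COc1ccc(-c2c(Nc3ccc(NC(C)=O)cc3)c3ccccc3oc2=O)cc1`: > 100000 nM (a limit)
Compound 2 `COc1ccc(-c2c(Nc3ccc(C)c(O)c3)c3ccc(OC)cc3oc2=O)cc1`: 34400 nM
Compound 3 `COc1ccc(-c2c(Nc3ccc(C)c(O)c3)c3ccc(O)cc3oc2=O)cc1`: > 100000 nM (a limit)

Compound 3 gives no number, only a limit, and it stands at the limit of > 100000 nM in this assay, at which 2 of the 3 values shown sit. Compound 4 `COc1ccc(-c2c(Nc3ccc(NC(C)=O)cc3)c3ccc(O)cc3oc2=O)cc1` has yet to be measured in this assay. It differs from compound 3 as follows: 4-acetamidophenyl in place of 3-hydroxy-4-methylphenyl on a nitrogen on an aromatic ring. In words, this is 4-acetamidophenyl in place of 3-hydroxy-4-methylphenyl on a nitrogen on an aromatic ring.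

Among the compounds with values here, no measured step covers this swap. Within the data shown here, the one measured step, an at least 2.9-fold higher number from compound 2 to compound 3 (0.46 log units; beyond the scatter), lies at another place on the core, but it shows that the core of compound 3 goes with the weaker reading. Compound 1 carries the same 4-acetamidophenyl group, and its value of > 100000 nM is also a limit. Compound 4 joins the core of compound 3 to the group of compound 1, and neither of those compounds gives a number in this assay. No step beyond the scatter is therefore expected, and a further limit is the likeliest report.

The expected change is a step that the limit leaves unreadable from compound 3 to compound 4. For compound 4 the estimate is 120000 nM, with an expected range from 50000 nM to 300000 nM.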

Compound 4, half-maximal inhibitory concentration: > 100000 nM
Compound 4: no number, only a limit; the forecaster's own chance of this, stated with the estimate: 75%; the middle value does not contradict the limit.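

In this assay compound 4 gives > 100000 nM, a limit and not a number. The steps to compound 4 from compound 3 and from compound 1 cannot be read, as all three readings are limits: the limit of > 100000 nM in this assay, at which 3 of the 4 values shown sit.

The compounds shown leave open how far 4-acetamidophenyl in place of 3-hydroxy-4-methylphenyl, or hydroxy in place of hydrogen, shifts the reading in this assay.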